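Halogen swap on the aryl ring of compound 1

The compounds below may be only part of what the source reports. "The series", "measured", "known", "first", "only" and "open" are said of these compounds alone.

Compound 1 `CCC(C(=O)N1CCN(c2cccc(Cl)c2)CC1)N1C(=O)CCC1=O` and compound 2 `CC(C(=O)N1CCN(c2cccc(Cl)c2)CC1)N1C(=O)CCC1=O` have both been tested in a functional assay on the whole organism (strain Swiss) with Mus musculus as the target, in the maximal electroshock model, with a stated time of 1 h, at a dose of 100 mg/kg by the intraperitoneal route; on this read-out lower numbers stand for a weaker effect and higher numbers for a stronger effect at the one dose given. Compound 1 gives 0%, while compound 2 gives 50%; compound 1 thus stands lowest of the two measured numbers. Going by the values given here, the only measured step, a number 50 percentage points higher from compound 1 to compound 2 (beyond the scatter), concerns hydrogen in place of methyl on a saturated chain carbon and leaves the aromatic ring untouched.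

Compound 3 `CCC(C(=O)N1CCN(c2cccc(F)c2)CC1)N1C(=O)CCC1=O` differs from compound 1 by fluoro in place of chloro on an aromatic carbon; the change sits on an aromatic carbon of a six-membered aromatic ring of carbon only, meta to a large group. Among the compounds with values here, no measured step bears on this change, and the series holds no pair that differs at the halogen. The expectation therefore rests on compound 1 alone, and the step of a number 10 percentage points higher from compound 1 to compound 3 (within the scatter) is expected to remain within the scatter. For compound 3 an activity of 10% is estimated, with a range from 0% to 40%.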

Compound 3, a percentage reported as activity, at one dose (the size of the read-out at that dose, not a potency): 0%
The estimate for compound 3 lay 10 percentage points above the measured number; the measured number falls inside the stated range.
By their numbers in this assay, from the lowest: compounds 1 and 3 (each within the scatter of the next); then compound 2.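

In this assay, going by these compounds alone, the change from 3-chlorophenyl to 3-fluorophenyl gives no change at the digits printed from compound 1 to compound 3 (within the scatter) and is the first reading at this aromatic position. Within the data shown here, on the core of compound 1, fluoro in place of chloro therefore brings no activity into view, while the only step beyond the scatter so far, a number 50 percentage points higher from compound 1 to compound 2 (beyond the scatter), remains the one on the saturated chain carbon. No measurement at hand offers an explanation for this result.

With compound 1 and compound 3 both giving no activity, the reading says nothing about how the halogen matters on the more active core of compound 2, where compound 2 gives 50% and a fluoro counterpart would be the direct test. Also open, going by these compounds, is whether a trifluoromethyl or methoxy group at this position, or a hydrogen in place of the halogen, would alter the read-out on either core.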